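This account rests on a few compounds, and the source may have more. Where it says the series, first, only, none or still open, it means among the compounds named here.

Measured in an ADME assay on BJ cells (Homo sapiens) for cytotoxicity, with a stated time of 72 h; a higher number here means that more compound is needed for the effect, a lower number that less compound is needed:
- compound 1 `CCc1ccc(-c2nc3c(c(C)nn3-c3ccccc3)c(-c3ccccc3O)c2C#N)cc1`: > 20000 nM
- compound 2 `CCc1ccc(-c2nc3c(c(C)nn3-c3ccccc3)c(-c3ccccc3C(=O)OC)c2C#N)cc1`: > 20000 nM
- compound 3 `CCc1cccc(-c2nc3c(c(C)nn3-c3ccccc3)c(-c3ccccc3O)c2C#N)c1`: > 20000 nM

Each of these values is a limit and not a number. Compound 1 therefore stands only at the limit > 20000 nM. The whole set shares this position: the limit of > 20000 nM in this assay, at which 3 of the 3 values shown sit.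

Compound 4 `CCc1ccc(-c2nc3c(c(-c4ccccc4)nn3-c3ccccc3)c(-c3ccccc3O)c2C#N)cc1` carries phenyl in place of methyl on an aromatic carbon. Within the data shown here, two measured steps bear on it only loosely, a step that the two limits leave unreadable from compound 1 to compound 2 and a step that the two limits leave unreadable from compound 1 to compound 3. Neither replaces the methyl, and neither has a readable size. No step beyond the scatter is therefore expected in this assay, and no direction can be given. The expected step is a number no higher from compound 1 to compound 4 (the limit leaves the size open). For compound 4 the estimate is 20000 nM, with an expected range from 8000 nM to 30000 nM.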

Compound 4, half-maximal effective concentration: > 20000 nM
Compound 4 gave a limit, no number (the forecaster's own chance of this, stated with the estimate: 70%); the middle value sits exactly at the limit.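

In this assay, among these compounds, compound 4 gives > 20000 nM and this is a limit, so no step from compound 1 to compound 4 can be read. The compounds shown leave open the actual concentration of each and whether any of these changes shifts it: the limit of > 20000 nM in this assay, at which 4 of the 4 values shown sit.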